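Swapping a Dichlorophenyl Arm for a Methoxyphenyl Arm

The source may hold more compounds than are shown below. What is called first, only, known or untested is meant among the compounds shown, and "the series" means these compounds.

Going by the values given here, compound 3 `COc1cc(N2C(N)=C(C#N)C(c3ccc(Cl)cc3Cl)C3=C2CC(C)(C)CC3=O)cc(OC)c1OC` is the only member of this small set with a numerical result in a functional assay on Ehrlich cells (Mus musculus) for cytotoxicity; on this read-out higher numbers stand for weaker inhibition and lower numbers for stronger inhibition: compound 3 gives 94700 nM, which on this read-out is a weak effect. Compound 1 `COc1cc(N2C(N)=C(C#N)C(c3c(OC)ccc4ccccc34)C3=C2CC(C)(C)CC3=O)cc(OC)c1OC` was recorded in this assay as "not active" (no number reported), and compound 2 `COc1cc(N2C(N)=C(C#N)C(c3ccc(OC)c4ccccc34)C3=C2CC(C)(C)CC3=O)cc(OC)c1OC` was recorded as "not active" (no number reported), so neither offers a number to compare with.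

Compound 4 `COc1ccccc1C1C(C#N)=C(N)N(c2cc(OC)c(OC)c(OC)c2)C2=C1C(=O)CC(C)(C)C2` differs from compound 3 in a single place: 2-methoxyphenyl in place of 2,4-dichlorophenyl on a saturated ring carbon. Among the compounds with values here, no pair of measured compounds shows what this kind of change does, so its effect cannot be read from the data. The expectation must rest on the weak starting point, because compound 3 already gives 94700 nM and the two related compounds gave no measurable value at all. The expected outcome is a step of a 1.4-fold higher number from compound 3 to compound 4 (0.14 log units; within the scatter) that stays within the usual scatter, or drifts toward weaker inhibition. For compound 4 the estimate in this assay is 130000 nM, with a range from 40000 nM to 400000 nM.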

Compound 4, half-maximal inhibitory concentration: 26600 nM
Estimate against measurement, compound 4: 4.9-fold (0.69 log units) above, and the stated range ends above it.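

Going by these compounds alone, putting 2-methoxyphenyl in place of 2,4-dichlorophenyl on this saturated ring carbon gives a 3.6-fold lower number from compound 3 to compound 4 (0.55 log units; beyond the scatter) in this assay, the first change in this set that can be read as a number. The step is modest but lies beyond the scatter, so the group at this position does affect the result, even though the heavy-atom count of the group and its six-membered aromatic ring stay the same. Nothing available explains why the number falls.

This single step swaps two chlorines for one methoxy group, so it cannot separate losing the chlorines from gaining the oxygen. Unsubstituted phenyl, 2-chlorophenyl or 2-ethoxyphenyl at this position would help tell those two apart, and the shown compounds leave open how far the effect could go.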